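The source may hold more compounds than are shown below. What is called first, only, known or untested is meant among the compounds shown, and "the series" means these compounds.

Of the compounds shown here, two have been measured in an assay on cell membranes for displacement of a labelled ligand from corticotropin-releasing factor receptor 1 (Rattus norvegicus); a lower number here means a stronger inhibitor, a higher number a weaker inhibitor. Compound 1 `CCN(CC)c1nc(C)nc2c(-c3cc(OC)c(OC)cc3Br)c(C)nn12` gives 4.06 nM. Compound 2 `CCN(CCC#N)c1nc(C)nc2c(-c3c(C)cc(OC)cc3OC)c(C)nn12` gives 2.48 nM. Compound 2 has the lower of the two numbers, but the gap to compound 1 lies within the usual scatter of this assay, so the two values cannot be told apart with confidence.

The open question concerns compound 3 `C=CCN(CC=C)c1nc(C)nc2c(-c3c(C)cc(OC)cc3OC)c(C)nn12`, which has not yet been measured in this assay. It differs from compound 2 in a single place: diallylamino in place of (2-cyanoethyl)(ethyl)amino on an aromatic carbon. The site is on an aromatic carbon of a six-membered aromatic ring with three nitrogen atoms, between two ring nitrogen atoms, and the rest of the shared core is unchanged.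

Within the data shown here, no step between two measured compounds is available at this position, so the expectation rests only on the two values already in hand. Both lie in a narrow band, and the change is a swap of one seven-heavy-atom amine substituent for another. The step from compound 2 to compound 3 is therefore expected to be small, most likely no larger than the scatter, with a slight lean towards a lower number, as a 1.2-fold lower number from compound 2 to compound 3 (0.09 log units; within the scatter). Compound 3 is estimated at 2 nM, within a range from 0.7 nM to 6 nM.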

Compound 3, half-maximal inhibitory concentration: 1 nM
Compound 3: middle estimate off by 2.0-fold (0.30 log units), on the high side; measured number inside the range.
By their numbers in this assay, from the lowest: compound 3; then compounds 2 and 1 (each within the scatter of the next).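

In this assay, the change from (2-cyanoethyl)(ethyl)amino to diallylamino on an aromatic carbon between two ring nitrogen atoms gives a 2.5-fold lower number from compound 2 to compound 3 (0.39 log units; beyond the scatter), a modest step but the first at this position to lie beyond the scatter. The two groups have the same heavy-atom count and neither has a ring, so the number at this site can shift even when the size of the substituent, counted this way, stays the same, and the nitrile is not required for a low number, as compound 3 gives 1 nM without one. Nothing measured here accounts for the step, so its origin remains unexplained.

With only this one step at the position, the compounds shown cannot separate a contribution of the two allyl groups from that of losing the 2-cyanoethyl chain. As far as these compounds go, how saturated chains such as dipropylamino, or a ring amine such as pyrrolidine or morpholine, would compare at this carbon on the otherwise unchanged core of compound 3 remains open.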